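Curcumin-like dienone series: hydroxy addition on the methoxyphenyl ring

The compounds below may be only part of what the source reports. "The series", "measured", "known", "first", "only" and "open" are said of these compounds alone.

Measured compounds:
compound 1 `COc1cccc(/C=C2\CCC/C(=C\c3ccc([N+](=O)[O-])cc3)C2=O)c1` — 5.82 ug/mL
compound 2 `COc1cccc(/C=C2\CCC/C(=C\c3ccc([N+](=O)[O-])cc3)C2=O)c1OC` — 13.3 ug/mL

In a functional assay on MCF7 cells (Homo sapiens) for cytotoxicity, read by MTT assay (on this read-out lower numbers stand for stronger inhibition and higher numbers for weaker inhibition), compound 1 gives 5.82 ug/mL and holds the lowest number of the two measured; in this assay compound 2 gives 13.3 ug/mL. Within the data shown here, the one measured step, a 2.3-fold higher number from compound 1 to compound 2 (0.36 log units; beyond the scatter), shows that a second methoxy on the same ring costs potency modestly.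

Compound 3 `COc1cc(/C=C2\CCC/C(=C\c3ccc([N+](=O)[O-])cc3)C2=O)ccc1O` is not yet measured. It differs from compound 1 by hydroxy in place of hydrogen on an aromatic carbon. Among the measured compounds shown here, no measured step covers a hydroxy at this place; the only step that bears on it is the addition of a methoxy to the same ring, which gave a 2.3-fold higher number from compound 1 to compound 2 (0.36 log units; beyond the scatter). A hydroxy shares the ring substitution pattern but not the group, so a small loss or no change beyond the scatter is expected rather than a large step. The expected step is a 1.3-fold higher number from compound 1 to compound 3 (0.11 log units; within the scatter); in this assay compound 3 is estimated at 7.5 ug/mL, with a range from 3 ug/mL to 18 ug/mL.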

Compound 3, half-maximal inhibitory concentration: 7.05 ug/mL
Compound 3: middle estimate off by 1.1-fold (0.03 log units), on the high side, and the stated range covers the measured number.
By their numbers in this assay, from the lowest: compounds 1, 3 and 2 (each within the scatter of the next, the first and the last beyond it).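

In this assay, hydroxy in place of hydrogen on an aromatic carbon, ortho to a methoxy group and para to a large group, gives a 1.2-fold higher number from compound 1 to compound 3 (0.08 log units; within the scatter). The change from 3-methoxyphenyl to 4-hydroxy-3-methoxyphenyl is therefore tolerated on this read-out, whereas the methoxy addition to the same ring gave a 2.3-fold higher number from compound 1 to compound 2 (0.36 log units; beyond the scatter), so among these compounds, a new group on this ring does not always bring a step beyond the scatter. No available data bear on what lies behind this result.

The compounds shown leave open whether a methoxy at this same place would read like the hydroxy of compound 3 or like the methoxy addition of compound 2. They also leave open how an amine or a carboxylic acid would read there.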